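A few compounds are considered here, and "the series" means these few. Any claim that something is new, unique, unknown or untested is made for them only; others in the source may bear on it.

Of the compounds shown here, three that share one core have been measured in a functional assay on OVCAR-3 cells (Homo sapiens) for inhibition, read by sulforhodamine B assay, with a stated time of 48 h; a higher number here means that more compound is tolerated, a lower number that less compound is tolerated. Compound 2 `COc1ccc(C(=O)/C=C/c2cc(-c3cc(OC)c(OC)c(OC)c3)n[nH]2)cc1OC` gives 5970 nM, the lowest of the two numbers shown. Compound 3 `COc1ccc(C(=O)/C=C/c2cc(-c3cc(OC)c(OC)c(OC)c3)n[nH]2)cc1` gives 7270 nM; the step of a 1.2-fold higher number from compound 2 to compound 3 (0.09 log units; within the scatter) stays within the scatter, so these two compounds cannot be ordered. Compound 1 `COc1cc(-c2cc(/C=C/C(=O)c3ccc(Cl)c(Cl)c3)[nH]n2)cc(OC)c1OC` reaches only a limit of this assay, > 100000 nM. That limit is the limit of > 100000 nM in this assay, at which 1 of the 3 values shown sits. The steps of an at least 16-fold lower number from compound 1 to compound 2 (1.22 log units; beyond the scatter) and an at least 13-fold lower number from compound 1 to compound 3 (1.13 log units; beyond the scatter) are large, but each exchanges the whole aryl group on the carbonyl carbon rather than a single substituent.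

Compound 4 `COc1cc(C(=O)/C=C/c2cc(-c3cc(OC)c(OC)c(OC)c3)n[nH]2)cc(OC)c1OC` differs from compound 2 by methoxy in place of hydrogen on an aromatic carbon. Among the compounds with values here, the only measured step that touches a single methoxy on that ring, a 1.2-fold higher number from compound 2 to compound 3 (0.09 log units; within the scatter), stayed within the scatter, so the step of a 1.1-fold lower number from compound 2 to compound 4 (0.04 log units; within the scatter) is expected to stay within the scatter as well. Compound 4 is therefore expected to give about 5500 nM, with a range from 2500 nM to 12000 nM.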

Compound 4, concentration lethal to 50% of the cells: 5790 nM
For compound 4 the middle estimate is 1.1-fold (0.02 log units) below the measured one; low and high end bracket the measured number.
By their numbers in this assay, from the lowest: compounds 4, 2 and 3 (each within the scatter of the next). At a limit, above all of these: compound 1.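

Adding a methoxy at this aromatic carbon, ortho to a methoxy group and meta to a second methoxy group, gives no readable change in this assay: the step is a 1.0-fold lower number from compound 2 to compound 4 (0.01 log units; within the scatter). The earlier compounds shown here showed only that taking a methoxy off this ring of compound 2 made no readable difference, and this result shows the same for putting one on, so both single changes around compound 2 now stay within the scatter. No measurement shown here accounts for this flat result.

The compounds shown carry only methoxy or hydrogen at this aromatic carbon, so a hydroxyl, an amine or a carboxylic acid there remains untested in this series. On these data alone, whether a single chlorine on this ring would shift the number also stays open.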